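Aryl amide exchange on a shared core: compound 4

A few compounds are considered here, and "the series" means these few. Any claim that something is new, unique, unknown or untested is made for them only; others in the source may bear on it.

Measured so far:
compound 1 `CCN(CC)CCNc1cc(C)c2cc(NC(=O)c3ccc(Cl)c(Cl)c3)ccc2n1`, 1420 nM
compound 2 `CCc1ccc(C(=O)Nc2ccc3nc(N4CCN(CC)CC4)cc(C)c3c2)cc1`, 3060 nM
compound 3 `CCN1CCN(c2cc(C)c3cc(NC(=O)c4ccc(OC)cc4)ccc3n2)CC1`, 7690 nM

In a functional assay on MCF7 cells (Homo sapiens) for antiproliferative activity, read by MTT assay, with a stated time of 72 h (a higher number here means a weaker inhibitor, a lower number a stronger inhibitor), compound 3 gives 7690 nM, the highest of the three numbers; compound 2 gives 3060 nM and compound 1 gives 1420 nM, both lower beyond the scatter.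

Compound 4 `CCN1CCN(c2cc(C)c3cc(NC(=O)c4ccco4)ccc3n2)CC1` differs from compound 3 by furan-2-yl in place of 4-methoxyphenyl on a carbonyl carbon. Among the compounds with values here, the only measured step touching this part of the series is a 2.5-fold higher number from compound 2 to compound 3 (0.40 log units; beyond the scatter), a change of a substituent on the aromatic ring rather than an exchange of the ring itself, so no step bears directly on the present change. Given the modest size of that step, a modest step in either direction is expected. Compound 4 is estimated at 8000 nM, with a range of 3000 nM to 20000 nM. The expected step is a 1.0-fold higher number from compound 3 to compound 4 (0.02 log units; within the scatter).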

Compound 4, half-maximal inhibitory concentration: 41200 nM
Beside the measured number, compound 4's estimate is 5.2-fold (0.71 log units) below it, and the stated range ends below it.
By their numbers in this assay, from the lowest: compound 1; then compound 2; then compound 3; then compound 4.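

In this assay, furan-2-yl in place of 4-methoxyphenyl on the carbonyl carbon gives a clear rise (a 5.4-fold higher number from compound 3 to compound 4 (0.73 log units; beyond the scatter)), and the comparison with 4-ethylphenyl gives a larger one (a 13-fold higher number from compound 2 to compound 4 (1.13 log units; beyond the scatter)). The aromatic ring itself on this carbonyl carbon therefore matters, not only the substituent it carries, and both substituted phenyl groups give lower numbers than furan-2-yl. Nothing available accounts for this rise. From the compounds shown here alone, whether a thiophene or a pyridine ring on the same carbonyl carbon would track furan-2-yl or the phenyl groups remains open.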